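The source may report more compounds than this note shows. Statements on the series, on what has been measured and on what is new or still open speak of the compounds shown alone.

Measured compounds:
- compound 1, `Cc1cc(Nc2cc(-c3ccccc3)[nH]n2)n2nc(SCc3csc4ccccc34)nc2n1`: 4420 nM
- compound 2, `Cc1cc(Nc2cc(-c3ccccc3)[nH]n2)n2nc(SCc3ccc(C(F)(F)F)cc3)nc2n1`: 4240 nM
- compound 3, `Cc1cc(Nc2cc(-c3ccccc3)[nH]n2)n2nc(SCc3ccccc3Br)nc2n1`: 5630 nM

These three compounds share a core and differ only in the aryl group on a saturated chain carbon bound to a sulfur. In a functional assay on PC-9 cells (Homo sapiens) for inhibition, read by MTT assay, with a stated time of 72 h (on this read-out lower numbers stand for stronger inhibition and higher numbers for weaker inhibition), compound 3 gives the highest of the three numbers, but it lies within the scatter of both neighbours: the step is a 1.3-fold higher number from compound 1 to compound 3 (0.11 log units; within the scatter) and a 1.3-fold higher number from compound 2 to compound 3 (0.12 log units; within the scatter), so no order among the three can be claimed.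

Compound 4, `Cc1cc(Nc2cc(-c3ccccc3)[nH]n2)n2nc(SCc3ccc(Br)cc3)nc2n1`, has not yet been measured. The change from compound 3 is 4-bromophenyl in place of 2-bromophenyl on a saturated chain carbon bound to a sulfur.

Going by the values given here, no measured step swaps one bromophenyl for another, so nothing bears on this change directly. Among the compounds with values here, what does bear on it is the general picture: every replacement of the aryl group at this position so far, a 1.0-fold lower number from compound 1 to compound 2 (0.02 log units; within the scatter), a 1.3-fold higher number from compound 1 to compound 3 (0.11 log units; within the scatter) and a 1.3-fold higher number from compound 2 to compound 3 (0.12 log units; within the scatter), has stayed within the scatter, whether the group was a fused bicycle, a trifluoromethyl-bearing phenyl or a bromophenyl. On that basis no step beyond the scatter is expected in this assay, in either direction, and the estimated step is a 1.2-fold lower number from compound 3 to compound 4 (0.07 log units; within the scatter). The expected value for compound 4 is 4800 nM, with a range from 2400 nM to 9600 nM.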

Compound 4, half-maximal inhibitory concentration: 4760 nM
The estimate for compound 4 lay 1.0-fold (0.00 log units) above the measured number; the range from low to high includes it.
By their numbers in this assay, from the lowest: compounds 2, 1, 4 and 3 (each within the scatter of the next).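

In this assay, the swap of 2-bromophenyl for 4-bromophenyl, which keeps the same atoms but joins them differently, gives a 1.2-fold lower number from compound 3 to compound 4 (0.07 log units; within the scatter), so within this pair the placement of the bromo group on the phenyl ring does not separate the two compounds. The new compound also stays within the scatter of the other two: bromo in place of trifluoromethyl on an aromatic carbon gives a 1.1-fold higher number from compound 2 to compound 4 (0.05 log units; within the scatter), and 4-bromophenyl in place of 1-benzothiophen-3-yl gives a 1.1-fold higher number from compound 1 to compound 4 (0.03 log units; within the scatter), so all four aryl groups on the saturated chain carbon bound to a sulfur now lie within the scatter of one another. No independent measurement is available that would offer an explanation for this flat result.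

The compounds shown all carry an aryl group at this position, so it remains open whether an amine, a carboxylic acid or a longer chain there would give a step beyond the scatter. They also share the same methyl group and phenyl-bearing pyrazole-side amine portion of the core, which leaves open how a change in those parts, such as a morpholine in place of the phenyl, would read in this assay.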